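Thiazolyl to pyridyl exchange on a sulfonamide, two cores

This account rests on a few compounds, and the source may have more. Where it says the series, first, only, none or still open, it means among the compounds named here.

Measured so far in a functional assay on HepG2 cells (Homo sapiens) for inhibition, read by sulforhodamine B assay, with a stated time of 24 h; on this read-out lower numbers stand for stronger inhibition and higher numbers for weaker inhibition:
compound 1, `N#Cc1c(-c2ccccc2)cn(-c2ccc(S(=O)(=O)Nc3nccs3)cc2)c1NC(N)=O`: 4020 nM
compound 2, `N#Cc1c(-c2ccccc2)cn(-c2ccc(S(=O)(=O)Nc3ccccn3)cc2)c1NC(N)=O`: 4120 nM
compound 3, `Cc1nc2c(c(-c3ccccc3)cn2-c2ccc(S(=O)(=O)Nc3nccs3)cc2)c(=O)[nH]1`: 3390 nM

Compound 1 and compound 2 share one core and differ only by pyridin-2-yl in place of 1,3-thiazol-2-yl on a sulfonamide nitrogen. In this assay this gives a 1.0-fold higher number from compound 1 to compound 2 (0.01 log units; within the scatter), so the two numbers cannot be told apart.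

Compound 3 carries a different core; the difference between the two cores is not broken down here. Its value in this assay lies within the scatter of both compound 1 and compound 2, so no order among the three can be read.

Compound 4, `Cc1nc2c(c(-c3ccccc3)cn2-c2ccc(S(=O)(=O)Nc3ccccn3)cc2)c(=O)[nH]1`, is compound 3 after (pyridin-2-yl in place of 1,3-thiazol-2-yl on a sulfonamide nitrogen). The place of this change, a sulfonamide nitrogen whose other neighbour is the sulfonyl sulfur, is the same as in the step from compound 1 to compound 2, so the change is the same.

For compound 4 in this assay a step of about a 1.0-fold higher number from compound 3 to compound 4 (0.01 log units; within the scatter) is expected, because the same exchange on the other core gave a 1.0-fold higher number from compound 1 to compound 2 (0.01 log units; within the scatter). The estimate for compound 4 is therefore 3500 nM, expected to fall between 1700 nM and 7200 nM.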

Compound 4, half-maximal inhibitory concentration: 3150 nM
Beside the measured number, compound 4's estimate is 1.1-fold (0.05 log units) above it; the range from low to high includes it.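

In this assay, pyridin-2-yl in place of 1,3-thiazol-2-yl on a sulfonamide nitrogen gives a 1.1-fold lower number from compound 3 to compound 4 (0.03 log units; within the scatter), so the two groups cannot be told apart on this core. Set beside the same exchange on the other core, the new step shows no difference in how the change carries over: the same change on two cores in this assay, a 1.0-fold higher number (0.01 log units; within the scatter) from compound 1 to compound 2 and a 1.1-fold lower number (0.03 log units; within the scatter) from compound 3 to compound 4, 1.1-fold (0.04 log units) apart, within the scatter of two such steps. Going by these compounds alone, this shows only that the exchange leaves the number unresolved from the scatter on these two cores in this one assay; it does not show that the exchange would behave the same way on a third core, nor that a step of real size would carry over, since neither step here is beyond the scatter.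

It remains open whether any group on the sulfonamide nitrogen moves the number, as both groups shown are aromatic rings and a short alkyl chain or a chain ending in an amine or a carboxylic acid would test this. The same question stands for the phenyl group on both cores.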